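A few compounds are considered here, and "the series" means these few. Any claim that something is new, unique, unknown or untested is made for them only; others in the source may bear on it.

Of the compounds shown here, three that share one core have been measured so far in an in vivo ADME assay on the whole organism for pharmacokinetics, with Canis familiaris (Canis lupus familiaris) as the target, at a dose of 0.6 mg/kg by the oral route; a lower number here means that a smaller share of the oral dose reaches the circulation, a higher number that a larger share of the oral dose reaches the circulation. Compound 1 `Cc1ccc([C@H](C(=O)N(C)C)N2C(=O)[C@@H](C3Cc4ccccc4C3)NC(=O)[C@H]2CC(C)C)cn1` gives 26%, the middle number of the three. Compound 2 `CC[C@H](C)[C@@H]1C(=O)N[C@H](C2Cc3ccccc3C2)C(=O)N1[C@@H](C(=O)N(C)C)c1ccc(C)[n+]([O-])c1` gives 11%, and compound 3 `CCC(CC)[C@@H]1C(=O)N[C@H](C2Cc3ccccc3C2)C(=O)N1[C@@H](C(=O)N(C)C)c1ccc(C)nc1` gives 47%.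

The unmeasured compound 4 `COc1ccc([C@H](C(=O)N(C)C)N2C(=O)[C@@H](C3Cc4ccccc4C3)NC(=O)[C@H]2CC(C)C)cn1` differs from compound 1 in one place: methoxy in place of methyl on an aromatic carbon, which turns 6-methylpyridin-3-yl into 6-methoxypyridin-3-yl (methoxy in place of methyl on an aromatic carbon).

Within the data shown here, only one measured step offers any guidance here. This is a number 21 percentage points higher from compound 1 to compound 3 (beyond the scatter), a modest change but one beyond the usual scatter. It concerns a different place, however, with pentan-3-yl in place of isobutyl on a saturated ring carbon. It therefore shows that a single change in this set can shift the number, but not what this particular exchange will do. Among the measured compounds shown here, no measured pair swaps methyl for methoxy, so the data give no firm direction.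

The best starting point is compound 1 at 26%, with no shift beyond the scatter expected. The expected change in this assay is an estimated a number 2 percentage points lower from compound 1 to compound 4 (within the scatter). For compound 4 the estimated value is 24%, with an expected range from 10% to 45%.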

Compound 4, oral bioavailability: 13%
Beside the measured number, compound 4's estimate is 11 percentage points above it; the measured number falls inside the stated range.
By their numbers in this assay, from the lowest: compounds 2 and 4 (each within the scatter of the next); then compound 1; then compound 3.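

In this assay, methoxy in place of methyl on the aromatic carbon next to the ring nitrogen gives a number 13 percentage points lower from compound 1 to compound 4 (beyond the scatter), so what sits at this position matters for how much of the oral dose reaches the circulation. Among these compounds, the only step readable earlier, a number 21 percentage points higher from compound 1 to compound 3 (beyond the scatter), lay at a saturated ring carbon and went upward, whereas this one shows that the aromatic ring is also sensitive and that the swap from 6-methylpyridin-3-yl to 6-methoxypyridin-3-yl moves the oral bioavailability downward. Nothing shown here bears on what lies behind this drop.

On these data alone, with a single step at this carbon, it stays open whether the fall belongs to methoxy alone or would also appear with other groups in its place, such as an amine, a fluorine atom or a longer chain like ethoxy. As far as these compounds go, it is also open whether the same exchange would lower the number to a similar extent when the pentan-3-yl group of compound 3 sits on the saturated ring carbon instead of the isobutyl group of compound 1.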